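The compounds below may be only part of what the source reports. "The series", "measured", "known", "first", "only" and "open" are said of these compounds alone.

Measured so far:
- Compound 1 `NS(=O)(=O)CC(=O)NCCSc1nonc1/C(=N/O)Nc1ccc(F)c(C(F)F)c1` — in an assay for inhibition of Indoleamine 2,3-dioxygenase 1 (Homo sapiens), read by fluorescence, with a stated time of 24 h (on this read-out higher numbers stand for weaker inhibition and lower numbers for stronger inhibition), compound 1 gives 13 nM.
- Compound 2 `CC(C)(O)CC(=O)NCCSc1nonc1/C(=N/O)Nc1ccc(F)c(C(F)F)c1` — in this assay compound 2 gives 8.4 nM.

Among the measured compounds shown here, compound 1 holds the highest of the two numbers, though its only neighbour is within the scatter: a 1.5-fold lower number from compound 1 to compound 2 (0.19 log units; within the scatter). That single step replaces one chain group with another on the amide side of the shared core and says nothing about the aromatic ring, which is left untouched in both measured compounds.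

Compound 3 `N#Cc1cc(N/C(=N\O)c2nonc2SCCNC(=O)CS(N)(=O)=O)ccc1F` is the next compound, still to be measured in this assay. It differs from compound 1 only at the ring: cyano in place of difluoromethyl on an aromatic carbon. For the measured compounds named here, no measured step touches this ring, so the step from compound 1 to compound 2 does not bear on the change, and the size of the effect has to be left open. Both measured numbers sit close together, which fixes the starting point well but gives no direction for a change at the aryl position.

Compound 3 is expected to come in around 25 nM, with a range from 8 nM to 80 nM. Relative to compound 1 this expectation corresponds to a 1.9-fold higher number from compound 1 to compound 3 (0.28 log units; within the scatter), with the direction uncertain.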

Compound 3, half-maximal inhibitory concentration: 39 nM
For compound 3 the middle estimate is 1.6-fold (0.19 log units) below the measured one; measured number inside the range.
By their numbers in this assay, from the lowest: compounds 2 and 1 (each within the scatter of the next); then compound 3.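

In this assay, the 3-(difluoromethyl)-4-fluorophenyl to 3-cyano-4-fluorophenyl change gives a 3.0-fold higher number from compound 1 to compound 3 (0.48 log units; beyond the scatter), a modest step beyond the scatter and the first read on this aromatic position, which the earlier pair left untouched. Among the compounds shown here, the position is therefore not indifferent to its substituent: with the sulfamoyl chain held constant, difluoromethyl gives stronger inhibition than cyano, while the only chain step so far, a 1.5-fold lower number from compound 1 to compound 2 (0.19 log units; within the scatter), stays within the scatter, although one step at each site cannot rank the two sites in general. Nothing shown accounts for the difference between difluoromethyl and cyano at this position.

On these data alone, it remains open whether the same ring change carries the same cost on the 1-hydroxy-1-methylethyl chain of compound 2, since only the sulfamoyl chain has been read with both ring groups. Also open, as far as these compounds go, is how other groups on this aromatic carbon, such as trifluoromethyl, chlorine, bromine or methyl, would fall relative to difluoromethyl and cyano, and whether any of them would give a lower number than compound 1.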